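Changing the Substituted Phenyl Group on a Shared Core

A few compounds are considered here, and "the series" means these few. Any claim that something is new, unique, unknown or untested is made for them only; others in the source may bear on it.

Compound 1 `Cc1oc(-c2ccc(Cl)cc2)nc1CN1CCC(C(=O)NCCCN2C[C@H](C)C[C@H](C)C2)CC1` was tested in an ADME assay on microsomes from liver (Rattus norvegicus) for metabolic stability, read by LC-MS, using NADPH, at 37 degrees C; on this read-out higher numbers stand for a longer-lived compound and lower numbers for a shorter-lived compound. In this assay compound 1 gives > 0.5 h, which is a limit of the assay rather than a number. Compound 2 `CCCN(CCC)CCNC(=O)C1CCN(Cc2nc(-c3ccccc3C)oc2C)CC1` was measured in the same way. In this assay compound 2 gives > 0.5 h, again a limit rather than a number. Both values sit at the limit of > 0.5 h in this assay, at which 2 of the 2 values shown sit, so neither compound can be placed above or below the other; all that is known is that both lasted past that point. Compound 3 `COc1cccc(Br)c1-c1nc(CN2CCC(C(=O)NCCCN3C[C@H](C)C[C@H](C)C3)CC2)c(C)o1` has not yet been measured. It differs from compound 1 in one place: 2-bromo-6-methoxyphenyl in place of 4-chlorophenyl on an aromatic carbon. Going by the values given here, no pair of measured compounds shows this kind of change, so its effect on stability in this assay is unknown. The step that the limit leaves unreadable from compound 1 to compound 3 is expected to be small, not beyond the usual scatter, in either direction. Compound 3 is therefore expected to give about 0.8 h in this assay, within a range from 0.4 h to 2 h, and it is quite possible that the assay will again report only a limit.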

Compound 3, half-life: 0.0583 h
Beside the measured number, compound 3's estimate is 14-fold (1.14 log units) above it; measured number below the stated range.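

This result shows that the aromatic carbon of the five-membered ring, next to the ring nitrogen and the ring oxygen, is not a place where any substituted phenyl group is tolerated equally: in this assay the exchange of 4-chlorophenyl for 2-bromo-6-methoxyphenyl gives an at least 8.5-fold lower number from compound 1 to compound 3 (0.93 log units; beyond the scatter) and so moves the compound to a clearly shorter life. Going by these compounds alone, the earlier compounds could not show this, as neither gave a number, whereas compound 3 gives the first real number on this read-out and shows that a compound with the shared core can fall well short of the limit. The step is only a minimum because compound 1 carries a limit and not a number: the limit of > 0.5 h in this assay, at which 2 of the 3 values shown sit.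

The change brings in a bromine and a methoxy group together, so what is shown cannot say which of them goes with the shorter life, and a 2-bromophenyl or a 2-methoxyphenyl group in the same place would separate the two. Going by these compounds, whether the same exchange would shorten the life of a compound with the dipropylamino side chain of compound 2 also stays open.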